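The source may report more compounds than this note shows. Statements on the series, on what has been measured and on what is new or still open speak of the compounds shown alone.

Of the compounds shown here, two have been measured so far. Compound 1 `Cc1cc(N/C=C2\C(=O)N(c3ccccc3)N=C2c2ccccc2)n[nH]1` gives 10200 nM in a functional assay on MDA-MB-453 cells (Homo sapiens) for antiproliferative activity, read by MTT assay, with a stated time of 72 h (on this read-out lower numbers stand for stronger inhibition and higher numbers for weaker inhibition), and compound 2 `O=C1/C(=C\Nc2cc[nH]n2)C(c2ccccc2)=NN1c1ccccc1` gives 34700 nM. Among the compounds with values here, compound 2 therefore stands with the higher of the two numbers, the only step seen being a 3.4-fold higher number from compound 1 to compound 2 (0.53 log units; beyond the scatter), where hydrogen took the place of methyl on an aromatic carbon. Compound 3 `O=C1/C(=C\Nc2cc(-c3ccccc3)[nH]n2)C(c2ccccc2)=NN1c1ccccc1` differs from compound 2 by phenyl in place of hydrogen on an aromatic carbon. That single step shows the position responds to substitution, though no phenyl has yet been tested there, so only a cautious expectation is possible. Compound 3 is estimated to give 10000 nM, between 2500 nM and 40000 nM. The expected step is a 3.5-fold lower number from compound 2 to compound 3 (0.54 log units; beyond the scatter).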

Compound 3, half-maximal inhibitory concentration: 8750 nM
For compound 3 the middle estimate is 1.1-fold (0.06 log units) above the measured one; the measured number falls inside the stated range.
By their numbers in this assay, from the lowest: compounds 3 and 1 (each within the scatter of the next); then compound 2.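

In this assay, phenyl in place of hydrogen gives a 4.0-fold lower number from compound 2 to compound 3 (0.60 log units; beyond the scatter), so this carbon of the five-membered ring tolerates a whole aromatic ring, not just a small methyl. Methyl and phenyl cannot be told apart here, with a 1.2-fold lower number from compound 1 to compound 3 (0.07 log units; within the scatter), so among these three compounds, having either group at this carbon goes with a lower number than hydrogen. No measurement is available to explain this result. Going by these compounds, whether an amine, a carboxylic acid or a longer chain at this carbon would fit the same picture stays open. So does the effect of a fluorine or methoxy group on the added phenyl.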